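A Repeated Aryl Swap and the Step It Should Bring

The source may hold more compounds than are shown below. What is called first, only, known or untested is meant among the compounds shown, and "the series" means these compounds.

Compound 1 `Fc1ccc(C2=NN(C3=NC(c4ccccc4)CS3)C(c3ccc4ccccc4c3)C2)cc1` gives 26500 nM in a functional assay on HepG2 cells (Homo sapiens) for inhibition, read by CCK-8 assay, with a stated time of 48 h; a higher number here means a weaker inhibitor, a lower number a stronger inhibitor.
Compound 2 `Cc1ccc(C2=NN(C3=NC(c4ccccc4)CS3)C(c3ccc4ccccc4c3)C2)cc1C` gives 7370 nM in this assay.
Compound 3 `O=C1CSC(N2N=C(c3ccc(F)cc3)CC2c2ccc3ccccc3c2)=N1` gives 24100 nM in this assay.

Compounds 1 and 2 share a core and differ by 3,4-dimethylphenyl in place of 4-fluorophenyl on a carbon with a double bond to nitrogen. That change gave a 3.6-fold lower number from compound 1 to compound 2 (0.56 log units; beyond the scatter). Compound 3 carries a different core, differing from compound 1 by a group of 6 heavy atoms (3 carbon, 1 nitrogen, 1 oxygen, 1 sulfur; one five-membered non-aromatic ring with 2 hetero atoms) in place of a group of 11 heavy atoms (9 carbon, 1 nitrogen, 1 sulfur; one five-membered non-aromatic ring with 2 hetero atoms, one six-membered aromatic ring of carbon only), on an amine nitrogen in a ring, a change that gave a 1.1-fold lower number from compound 1 to compound 3 (0.04 log units; within the scatter), so the two cores sit close together in this assay.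

Compound 4 `Cc1ccc(C2=NN(C3=NC(=O)CS3)C(c3ccc4ccccc4c3)C2)cc1C` is not yet measured. It differs from compound 3 by 3,4-dimethylphenyl in place of 4-fluorophenyl on a carbon with a double bond to nitrogen. Going by the values given here, this is the same kind of change as the one from compound 1 to compound 2, though the surroundings differ: in compound 1 the place lies two ring bonds from the ring atom that bears a large group and two ring bonds from the ring atom that bears a naphthalen-2-yl group, whereas in compound 3 it lies two ring bonds from the ring atom that bears a group of 6 heavy atoms and two ring bonds from the ring atom that bears a large group. Because compound 3 gives 24100 nM, near compound 1, the same kind of change is expected to bring a step of about a 3.4-fold lower number from compound 3 to compound 4 (0.54 log units; beyond the scatter). Compound 4 is therefore estimated at 7000 nM, with a range expected from 3000 nM to 16000 nM.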

Compound 4, half-maximal inhibitory concentration: 8490 nM
Estimate against measurement, compound 4: 1.2-fold (0.08 log units) below; low and high end bracket the measured number.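

In this assay, 3,4-dimethylphenyl in place of 4-fluorophenyl again lowers the number on the second core, with a 2.8-fold lower number from compound 3 to compound 4 (0.45 log units; beyond the scatter), and this step matches the earlier one on the core of compound 1: the same change on two cores in this assay, a 3.6-fold lower number (0.56 log units; beyond the scatter) from compound 1 to compound 2 and a 2.8-fold lower number (0.45 log units; beyond the scatter) from compound 3 to compound 4, 1.3-fold (0.10 log units) apart, within the scatter of two such steps. The exchange of cores likewise gives no step beyond the scatter when 3,4-dimethylphenyl is present, with a 1.2-fold higher number from compound 2 to compound 4 (0.06 log units; within the scatter), and it agrees with the exchange made with 4-fluorophenyl present: the same change on two cores in this assay, a 1.1-fold lower number (0.04 log units; within the scatter) from compound 1 to compound 3 and a 1.2-fold higher number (0.06 log units; within the scatter) from compound 2 to compound 4, 1.3-fold (0.10 log units) apart, within the scatter of two such steps. So across these four compounds the aryl change carries from one core to the other without a detectable change in size, but this rests on a single change and a single pair of cores, and it shows neither why the number falls nor that the step would hold on any further core.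

The compounds shown leave open whether other groups at this place, such as 4-methoxyphenyl or a pyridine ring, would give matching steps on both cores. They also leave open whether these steps would persist if a simple phenyl replaced the naphthalen-2-yl group.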